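Removing the Side Chain: From Compound 3 to Compound 4

A few compounds are considered here, and "the series" means these few. Any claim that something is new, unique, unknown or untested is made for them only; others in the source may bear on it.

Compound 3 `COCCNc1nc(-c2ccccc2)cc2c1c(N)nn2C` gives 2% in an assay on isolated protein for inhibition of MAP kinase-activated protein kinase 2 (Homo sapiens), read by mobility shift assay, tested at 30 uM; a lower number here means less inhibition, a higher number more inhibition at the concentration tested (going by the name of the read-out). That number is level with compound 1 `Cc1cc2c(c(N)nn2C)c(N2CC[C@H](O)C2)n1`, which gives 2%, and together the two are the lowest of the three; compound 2 `COCCNc1nc(C)cc2c1c(N)nn2C` gives 6%, the step of a number 4 percentage points lower from compound 2 to compound 3 (within the scatter) lying within the scatter. Compound 4 `Cn1nc(N)c2cnc(-c3ccccc3)cc21` differs from compound 3 by hydrogen in place of (2-methoxyethyl)amino on an aromatic carbon. Within the data shown here, the one measured step that bears on the same kind of change is a number 4 percentage points higher from compound 1 to compound 2 (within the scatter), where one group gave way to another at an aromatic carbon and the read-out moved only within the scatter. Nothing measured here points to a shift beyond the scatter, so the step of a number 1 percentage points higher from compound 3 to compound 4 (within the scatter) is expected to be small. Compound 4 is therefore estimated at 3%, within -8% to 14%.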

Compound 4, a percentage reported as inhibition, at one concentration (the size of the read-out at that concentration, not a potency): 7%
The estimate for compound 4 lay 4 percentage points below the measured number; the measured number falls inside the stated range.
By their numbers in this assay, from the lowest: compounds 1, 3, 2 and 4 (each within the scatter of the next).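

Replacing (2-methoxyethyl)amino with hydrogen on the aromatic carbon next to the ring nitrogen gives a number 5 percentage points higher from compound 3 to compound 4 (within the scatter) in this assay. The earlier step at this carbon only exchanged one substituent for another, whereas this one shows that, with phenyl on the core, the read-out stays within the scatter even with no side chain there. Nothing measured explains this result.

From the compounds shown here alone, whether a carboxylic acid or a longer amine chain at this carbon would move the read-out beyond the scatter remains open.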